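The source may hold more compounds than are shown below. What is called first, only, known or untested is meant among the compounds shown, and "the series" means these compounds.

In a functional assay on the whole organism with Rattus norvegicus as the target (a lower number here means that less compound is needed, a higher number that more compound is needed for the effect), compound 1 `CCOCCOC(=O)C(=O)Nc1nc(-c2cc(OC)no2)cs1` gives 3 mg/kg. Compound 2 `CCOCCOC(=O)C(=O)Nc1nc(-c2conc2C)cs1` reaches only a limit, > 100 mg/kg. Compound 3 `CCOCCOC(=O)C(=O)Nc1nc(-c2cc(C)on2)cs1` gives 1.3 mg/kg, the lower of the two actual numbers, and the step to it is a 2.3-fold lower number from compound 1 to compound 3 (0.36 log units; beyond the scatter). Compound 4 `Cc1cc(-c2csc(NC(=O)C(=O)O)n2)no1` has hydrogen in place of 2-ethoxyethyl on an oxygen next to a carbonyl group, (hydrogen in place of 2-ethoxyethyl on an oxygen next to a carbonyl group). Within the data shown here, no measured step touches this place. The steps of an at least 33-fold higher number from compound 1 to compound 2 (1.52 log units; beyond the scatter) and an at least 76-fold lower number from compound 2 to compound 3 (1.88 log units; beyond the scatter) change only the methyl- or methoxy-bearing ring group, so they show merely that one change can matter greatly here. A modest rise is expected, held loosely, and the estimated step is a 3.1-fold higher number from compound 3 to compound 4 (0.49 log units; beyond the scatter). Compound 4 is estimated at 4 mg/kg, with an expected range of 0.5 mg/kg to 40 mg/kg.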

Compound 4, dose for half-maximal effect: 1.7 mg/kg
Beside the measured number, compound 4's estimate is 2.4-fold (0.37 log units) above it; the measured number falls inside the stated range.
By their numbers in this assay, from the lowest: compounds 3, 4 and 1 (each within the scatter of the next, the first and the last beyond it). At a limit, above all of these: compound 2.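

Among these compounds, the earlier steps touched only the methyl- or methoxy-bearing ring group, so this is the first reading on the oxygen next to a carbonyl group. In this assay, hydrogen in place of 2-ethoxyethyl gives a 1.3-fold higher number from compound 3 to compound 4 (0.12 log units; within the scatter), so losing the whole chain leaves no difference beyond the usual scatter. Nothing measured here accounts for this result.

Still open, from the compounds shown here alone, is how an amine in place of 2-ethoxyethoxy, or a methyl or a longer chain on that oxygen, would read. Also open, going by these compounds, is whether hydroxy would read the same alongside the ring groups of compound 1 and compound 2.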